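A bromo step from an inactive compound

This account rests on a few compounds, and the source may have more. Where it says the series, first, only, none or still open, it means among the compounds named here.

compound 1 `O=C(CCCCC1CCSS1)NO`: 2.57%
compound 2 `O=C(CCCCC1CCSS1)Nc1ccc(OC(F)(F)F)cc1`: 1.54%
compound 3 `O=C(CCCCC1CCSS1)Nc1ccccn1`: "not active" (no number reported)

These compounds were tested in a functional assay on KB cells (Homo sapiens) for inhibition, read by MTT assay, with a stated time of 24 h, tested at 1 ug/mL; on this read-out higher numbers stand for more inhibition of growth at the one concentration tested and lower numbers for less inhibition of growth. Only one concentration was used. Each result shows how much growth was stopped at that dose and does not give a full dose-response curve. Compound 3 has no single number and was simply reported as "not active" (no number reported). The figures available for comparison are both close to zero: compound 1 gives 2.57% and compound 2 gives 1.54%, and these two values lie within the usual scatter of each other.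

Compound 4 `O=C(CCCCC1CCSS1)Nc1ccc(Br)cn1` has not yet been measured. It differs from its parent by one change: bromo in place of hydrogen on an aromatic carbon. For the measured compounds named here, no measured pair here shows what such a swap does in this assay, so there is no direct guide. The nearest clue is compound 2, which also carries a substituted aromatic ring and gives only 1.54%. No step beyond the usual scatter is therefore expected, and the result may again come without a number. For compound 4 the estimated inhibition is 3%, with an expected range of 0% to 12%.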

Compound 4, percent growth inhibition at one concentration: 4.33%
Estimate against measurement, compound 4: 1.3 percentage points below, within the range that was stated.
By their numbers in this assay, from the lowest: compounds 2, 1 and 4 (each within the scatter of the next).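

For the compounds shown here, compound 3 carries no number and compound 4 gives 4.33% in this assay, so no step between the two can be read. No measurement shown here bears on the reason for this result. The compounds shown leave open what bromo in place of hydrogen does to growth inhibition, and how they behave at other concentrations.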